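Halogen swap on the aryl ketone of compound 2

The source may report more compounds than this note shows. Statements on the series, on what has been measured and on what is new or still open speak of the compounds shown alone.

Compound 1 `Cc1ccccc1NC(=O)CSc1nncnc1-c1cccc2ccccc12`: 158000 nM
Compound 2 `O=C(CSc1nncnc1-c1ccccc1Cl)c1ccc(Cl)c(Cl)c1`: 33000 nM

In an ADME assay on MT4 cells (Homo sapiens) for cytotoxicity, read by MTT assay (on this read-out lower numbers stand for higher toxicity in this test and higher numbers for lower toxicity in this test), compound 2 gives 33000 nM, the lower of the two numbers measured; compound 1 gives 158000 nM, and the gap between them lies beyond the scatter. For the measured compounds named here, the two measured compounds differ in more than one place, so no single step between them can be read off.

Compound 3 `O=C(CSc1nncnc1-c1ccccc1Cl)c1ccc(Br)cc1Br` is not yet measured. It differs from compound 2 as follows: 2,4-dibromophenyl in place of 3,4-dichlorophenyl on a carbonyl carbon. Going by the values given here, with no measured pair to anchor the step, the expectation rests on the closeness of the two groups as counted above. The step from compound 2 to compound 3 in this assay is expected to be small, a 1.1-fold lower number from compound 2 to compound 3 (0.04 log units; within the scatter), with no clear direction beyond the scatter. Compound 3 is therefore estimated at 30000 nM, within a range from 10000 nM to 100000 nM.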

Compound 3, half-maximal cytotoxic concentration: 28000 nM
Compound 3: the middle estimate sits 1.1-fold (0.03 log units) above what was measured; the measured number falls inside the stated range.
By their numbers in this assay, from the lowest: compounds 3 and 2 (each within the scatter of the next); then compound 1.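

For the compounds shown here, the first step that can be read at this place comes from the swap of 3,4-dichlorophenyl for 2,4-dibromophenyl on a carbonyl carbon: in this assay it is a 1.2-fold lower number from compound 2 to compound 3 (0.07 log units; within the scatter). Thus, at this place, two groups with the same count of heavy atoms, but different halogens and a different halogen pattern, are not told apart in this test. No measurement shown here bears on why they read alike.

Going by these compounds, the step changes halogen and pattern together, so the share of each remains open. On these data alone, it also remains open whether a plain phenyl, or a phenyl carrying an amine or a carboxylic acid, on the same carbonyl carbon would move the number beyond the scatter.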